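Aryl variation on the shared core: from compound 3 to compound 4

The source may hold more compounds than are shown below. What is called first, only, known or untested is meant among the compounds shown, and "the series" means these compounds.

Compound 1 `CCCS(=O)(=O)Nc1ccc(F)c(C(=O)c2n[nH]c3ncc(-c4ccccc4O)cc23)c1F` gives 9% in an assay for binding affinity to dual specificity mitogen-activated protein kinase kinase 4 (Homo sapiens), read by KINOMEscan, tested at 100 nM; on this read-out lower numbers stand for a stronger effect and higher numbers for a weaker effect at the one concentration tested.
Compound 2 `CCCS(=O)(=O)Nc1ccc(F)c(C(=O)c2n[nH]c3ncc(-c4ccc(N(C)C)cc4)cc23)c1F` gives 2.5% in this assay.
Compound 3 `CCCS(=O)(=O)Nc1ccc(F)c(C(=O)c2n[nH]c3ncc(-c4ccc(Cl)c(Cl)c4)cc23)c1F` gives 45% in this assay.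

Compound 3 gives the highest number of the three, the weakest effect here; the gaps to both others are beyond the scatter, with a number 36 percentage points higher from compound 1 to compound 3 (beyond the scatter) and a number 42.5 percentage points higher from compound 2 to compound 3 (beyond the scatter), while a number 6.5 percentage points lower from compound 1 to compound 2 (within the scatter) lies within it. Compound 4 `CCCS(=O)(=O)Nc1ccc(F)c(C(=O)c2n[nH]c3ncc(-c4ccc(-c5nnn[nH]5)cc4)cc23)c1F` is not yet measured. The change is 4-(1H-tetrazol-5-yl)phenyl in place of 3,4-dichlorophenyl on an aromatic carbon. Among the compounds with values here, no measured step covers a tetrazolylphenyl group, so the bearing steps are only the two large ones leading to compound 3; both show that exchanging the 3,4-dichlorophenyl for another aryl group lowered the number substantially. A downward step is therefore expected, with wide uncertainty: compound 4 is estimated at 15%, between 3% and 45%, meaning an expected step of a number 30 percentage points lower from compound 3 to compound 4 (beyond the scatter).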

Compound 4, a percentage reported as activity, at one concentration (the size of the read-out at that concentration, not a potency): 0.15%
Beside the measured number, compound 4's estimate is 14.9 percentage points above it, and the stated range ends above it.
By their numbers in this assay, from the lowest: compounds 4, 2 and 1 (each within the scatter of the next); then compound 3.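

In this assay the larger 4-(1H-tetrazol-5-yl)phenyl group is accepted at this aromatic carbon, and a number 44.9 percentage points lower from compound 3 to compound 4 (beyond the scatter) shows that a second ring on the aryl group does not cost effect here. It does not separate from the earlier aryl groups, with a number 2.4 percentage points lower from compound 2 to compound 4 (within the scatter) and a number 8.9 percentage points lower from compound 1 to compound 4 (within the scatter) both small enough to leave these three unranked. No measured evidence accounts for this result.

Still open, going by these compounds, is whether a carboxylic acid or a morpholine in place of the 1H-tetrazol-5-yl gives the same reading. The single tested concentration also leaves open whether any of compounds 1, 2 and 4 has a stronger or weaker effect than the others at other concentrations.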